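The Same Amine Exchange Tried on a Second Core

The source may hold more compounds than are shown below. What is called first, only, known or untested is meant among the compounds shown, and "the series" means these compounds.

Measured compounds:
compound 1, `CCCCc1sc(-c2ccc(Oc3ccc(Cl)cc3)cc2)nc1-c1ccc(OCCCN(CC)CC)cc1`, 57%
compound 2, `CCCCc1sc(-c2ccc(Oc3ccc(Cl)cc3)cc2)nc1-c1ccc(OCC2CCCN(CC)C2)cc1`, 55.9%
compound 3, `CCCCc1nc(-c2ccc(OCCCN(CC)CC)cc2)sc1-c1ccc(Oc2ccc(Cl)cc2)cc1`, 49.6%

The three compounds were tested in an assay on isolated protein for antagonist activity at advanced glycosylation end product-specific receptor (Homo sapiens), read by ELISA, with a stated time of 60 min, tested at 10 uM; on this read-out higher numbers stand for more inhibition at the one concentration tested (going by the name of the read-out) and lower numbers for less inhibition. Compound 1 and compound 2 share a core and differ only by 1-ethylpiperidin-3-yl in place of 2-(diethylamino)ethyl on a saturated chain carbon bound to an oxygen on an aromatic ring; this gave a number 1.1 percentage points lower from compound 1 to compound 2 (within the scatter). Compound 3 has the same atoms as compound 1 joined differently; the difference between the two cores is not broken down here, and their two values in this assay lie within the scatter of each other.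

Compound 4, `CCCCc1nc(-c2ccc(OCC3CCCN(CC)C3)cc2)sc1-c1ccc(Oc2ccc(Cl)cc2)cc1`, has not yet been measured. It stands to compound 3 as compound 2 stands to compound 1: 1-ethylpiperidin-3-yl in place of 2-(diethylamino)ethyl on a saturated chain carbon bound to an oxygen on an aromatic ring, the same change at the same kind of place. From this one precedent, the step is expected to be a number 1.6 percentage points lower from compound 3 to compound 4 (within the scatter), because a number 1.1 percentage points lower from compound 1 to compound 2 (within the scatter). Compound 4 is therefore estimated at 48%, with a likely range from 36% to 60%.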

Compound 4, a percentage reported as inhibition, at one concentration (the size of the read-out at that concentration, not a potency): 47.7%
Estimate against measurement, compound 4: 0.3 percentage points above, and the stated range covers the measured number.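

In this assay, placing 1-ethylpiperidin-3-yl where 2-(diethylamino)ethyl had been gave a number 1.9 percentage points lower from compound 3 to compound 4 (within the scatter). Set beside the earlier step, the change read the same on both cores: the same change on two cores in this assay, a number 1.1 percentage points lower (within the scatter) from compound 1 to compound 2 and a number 1.9 percentage points lower (within the scatter) from compound 3 to compound 4, 0.8 percentage points apart, within the scatter of two such steps. This shows that on these two cores the exchange left the reading within the scatter, but two small steps at one concentration say nothing about potency or about how the change would read on a further core.

The compounds shown leave open how a different amine, such as a morpholine or a pyrrolidine, would read on either core. They also leave open what a carboxylic acid in place of the amine would do.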